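The compounds below may be only part of what the source reports. "The series", "measured", "known", "first", "only" and "open" are said of these compounds alone.

Working notes on the series. The read-out throughout is a functional assay on HeLa cells (Homo sapiens) for cytotoxicity, read by CCK-8 assay; on this read-out lower numbers stand for stronger inhibition and higher numbers for weaker inhibition. Compound 1 `Oc1cccc(-c2cc(-c3ccsc3)cc(-c3cccc(O)c3)n2)c1` gives 16600 nM in this assay, and compound 2 `Oc1ccc(-c2cc(-c3ccsc3)cc(-c3cccc(O)c3)n2)cc1` gives 2580 nM. The change between them is 4-hydroxyphenyl in place of 3-hydroxyphenyl on an aromatic carbon, and it made the step of a 6.4-fold lower number from compound 1 to compound 2 (0.81 log units; beyond the scatter). Compound 3 `Oc1cccc(-c2cc(-c3ccoc3)cc(-c3ccccc3O)n2)c1` belongs to a second core; how its core differs from that of compound 1 is not broken down here. In this assay compound 3 gives > 50000 nM, which is a limit of the assay and not a number. One of the three values reported sits at this limit (the limit of > 50000 nM in this assay, at which 1 of the 3 values shown sits). Compound 4 `Oc1ccc(-c2cc(-c3ccoc3)cc(-c3ccccc3O)n2)cc1` is not yet measured. It differs from compound 3 by 4-hydroxyphenyl in place of 3-hydroxyphenyl on an aromatic carbon, the same kind of change as from compound 1 to compound 2, though the surroundings differ: here the place is meta to a 2-hydroxyphenyl group and meta to a furan-3-yl group, whereas before it was meta to a 3-hydroxyphenyl group and meta to a thiophen-3-yl group. Resting on the step from compound 1 to compound 2, the expected step is an at least 2.5-fold lower number from compound 3 to compound 4 (0.39 log units; beyond the scatter), set against a 6.4-fold lower number from compound 1 to compound 2 (0.81 log units; beyond the scatter), though compound 3 only gives a limit. Compound 4 is estimated at 20000 nM, expected between 5000 nM and 80000 nM.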

Compound 4, half-maximal inhibitory concentration: > 50000 nM
Compound 4: only a limit was reported (the forecaster's own chance of this, stated with the estimate: 35%); middle value at least 2.5-fold (0.39 log units) from the limit.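

Within the data shown here, no step from compound 3 to compound 4 can be read, since both stand at the same limit of the assay and neither gives a number: the limit of > 50000 nM in this assay, at which 2 of the 4 values shown sit. The compounds shown leave open whether 4-hydroxyphenyl in place of 3-hydroxyphenyl changes the read-out at all on the core of compound 3, as it does on the core of compound 1.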